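The compounds below may be only part of what the source reports. "The series", "measured", "known", "first", "only" and "open" are said of these compounds alone.

Measured in a functional assay on B16 cells (Mus musculus) for cytotoxicity, read by MTT assay, with a stated time of 48 h; on this read-out lower numbers stand for stronger inhibition and higher numbers for weaker inhibition:
compound 1 `O=C(Nc1cccc(-c2cn(Cc3ccccc3)nn2)c1)c1cn(Cc2ccccc2)nn1`: 4500 nM
compound 2 `CCOC(=O)Cn1cc(C(=O)Nc2cccc(-c3cn(Cc4ccccc4)nn3)c2)nn1`: 20400 nM

Of the two, compound 2 has the higher number, 20400 nM, and so is the weaker inhibitor. Going by the values given here, the only measured step, a 4.5-fold higher number from compound 1 to compound 2 (0.66 log units; beyond the scatter), is modest but beyond the scatter. It came from ethoxycarbonyl replacing phenyl, and it shows that a change at this place can move the number.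

Compound 3 `CC(=O)OCCn1cc(C(=O)Nc2cccc(-c3cn(Cc4ccccc4)nn3)c2)nn1` has the same atoms as compound 2, joined differently: acetoxymethyl in place of ethoxycarbonyl on a saturated chain carbon bound to an aromatic nitrogen. In words, acetoxymethyl stands in place of ethoxycarbonyl on a saturated chain carbon bound to an aromatic nitrogen. Among the compounds with values here, no measured step tests this rearrangement directly, and the counted features stay the same, so a smaller change than the measured one seems likely. No clear direction can be drawn from the data, and no shift beyond the scatter is expected. The expected step is a 1.3-fold lower number from compound 2 to compound 3 (0.11 log units; within the scatter). Compound 3 is therefore estimated at 16000 nM, with an expected range from 6000 nM to 40000 nM.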

Compound 3, half-maximal inhibitory concentration: > 100000 nM
Compound 3: no number, only a limit (the forecaster's own chance of this, stated with the estimate: 10%); middle value at least 6.2-fold (0.79 log units) from the limit.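

Compound 3 gives only a limit, not a number, in this assay: the limit of > 100000 nM in this assay, at which 1 of the 3 values shown sits. With the same atoms joined differently, the change from ethoxycarbonyl to acetoxymethyl gives an at least 4.9-fold higher number from compound 2 to compound 3 (0.69 log units; beyond the scatter), so at this place the way the atoms are joined matters, not just which atoms are present. Acetoxymethyl in place of phenyl gives an at least 22-fold higher number from compound 1 to compound 3 (1.34 log units; beyond the scatter), a wider span than the earlier step showed, and compound 1, with phenyl, remains the strongest inhibitor of the three.

As far as these compounds go, since compound 3 has only a limit, the full size of both steps stays open. Also open, from the compounds shown here alone, is whether a carboxylic acid in place of ethoxycarbonyl, a free hydroxyl in place of acetoxymethyl, or an amine on the same chain would keep the number near that of compound 2 or push it towards that of compound 3.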